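The source may hold more compounds than are shown below. What is called first, only, known or untested is meant among the compounds shown, and "the series" means these compounds.

In an ADME assay on the whole organism for inhibition, with Echinochloa crus-galli var. formosensis as the target (on this read-out lower numbers stand for stronger inhibition and higher numbers for weaker inhibition), compound 3 `CCN(CC)c1nc(Cl)nc(N[C@H](C)c2ccccc2)n1` gives 21400 nM. This is level with compound 1 `CCN(CC)c1nc(Cl)nc(NC(C)c2ccccc2)n1` at 17800 nM, while compound 2 `CCNc1nc(Cl)nc(N[C@@H](C)c2ccccc2)n1` lies far lower at 17.4 nM.

Compound 4 `CCN(CC)c1nc(Cl)nc(N[C@@H](C)c2ccccc2)n1` is the next point, and its change from compound 3 is the two compounds have the same atoms and bonds and differ only in configuration as drawn: 1 of 1 stereo elements differ; a stereocentre at a saturated chain carbon is drawn R in compound 3 and S in compound 4. The stereocentre is the only thing that moves, and no group leaves or enters.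

Among the compounds with values here, one measured step bears on this: a 1.2-fold higher number from compound 1 to compound 3 (0.08 log units; within the scatter). What separates that pair is the fact that one of compounds 1 and 3 is drawn with a defined configuration and the other without, at the place where they differ. Were compound 1 an equal mixture of compound 3 and compound 4, which the data do not state, a very strong compound 4 would have drawn the mixture well away from compound 3. The step shows no such pull.

A modest move toward lower numbers in this assay is therefore expected, near the edge of the scatter, and the mixture remains an assumption. The expected step is a 2.1-fold lower number from compound 3 to compound 4 (0.33 log units; beyond the scatter). Compound 4 is estimated at 10000 nM, with an expected range of 2500 nM to 30000 nM.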

Compound 4, half-maximal inhibitory concentration: 19100 nM
Compound 4: the middle estimate sits 1.9-fold (0.28 log units) below what was measured, and the stated range covers the measured number.
By their numbers in this assay, from the lowest: compound 2; then compounds 1, 4 and 3 (each within the scatter of the next).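

In this assay the two drawn configurations at the saturated chain carbon stand level (a 1.1-fold lower number from compound 3 to compound 4 (0.05 log units; within the scatter)), and the form drawn without a configuration stands level with the S form too (a 1.1-fold higher number from compound 1 to compound 4 (0.03 log units; within the scatter)). Neither configuration in this pair bearing the extra ethyl comes near compound 2 (17.4 nM). The ethyl in place of hydrogen on a nitrogen on an aromatic ring can now be read as a single change with S drawn on both sides, and the large gap remains (a 1100-fold higher number from compound 2 to compound 4 (3.04 log units; beyond the scatter)).

Whether configuration counts when that nitrogen carries only one ethyl stays open, as the R partner of compound 2 is not among the compounds shown. On these data alone, how a propyl chain or a morpholine ring at that nitrogen would read also stays open.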